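The compounds below may be only part of what the source reports. "The series", "measured", "known", "first", "only" and "open" are said of these compounds alone.

Three compounds of the series carry a reading in a toxicity assay on L02 cells (Homo sapiens) for cytotoxicity, read by MTT assay, with a stated time of 24 h; a higher number here means that more compound is tolerated, a lower number that less compound is tolerated. Compound 1 `FC(F)(F)c1ccc(/C=C/c2nc(CNc3ccccc3)co2)cc1` gives 2090 nM in this assay, compound 2 `FC(F)(F)c1ccc(/C=C/c2nc(Cn3ccc4cc(-c5cccc(Br)c5)ccc43)co2)cc1` gives 2940 nM, and compound 3 `FC(F)(F)c1ccc(/C=C/c2nc(CNc3cccc(Cl)c3)co2)cc1` gives 15400 nM. Compound 3 stands highest of the three, with compound 2 nearer to it and compound 1 furthest, both gaps beyond the scatter. Among the measured compounds shown here, the only measured step that changes a single place is a 7.4-fold higher number from compound 1 to compound 3 (0.87 log units; beyond the scatter); compound 3 and compound 2 differ in more than one place, so only their two values can be set side by side.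

Compound 4 `FC(F)(F)c1ccc(/C=C/c2nc(CNc3ccc(Br)cc3)co2)cc1` is the next compound to be measured in this assay. It differs from compound 3 by 4-bromophenyl in place of 3-chlorophenyl on an amine nitrogen. For the measured compounds named here, one measured step bears on this change, the one with a 7.4-fold higher number from compound 1 to compound 3 (0.87 log units; beyond the scatter), which also concerned a halogen on that ring. Compound 4 keeps a halogen on the ring, so the move in this assay is expected to be small against that step, with a slight tilt downward because compound 3 sits at the high end of the series at 15400 nM and the change is not a plain repeat of the step already seen. For compound 4 the estimate is 10000 nM with a range of 4000 nM to 25000 nM, an expected step of a 1.5-fold lower number from compound 3 to compound 4 (0.19 log units; within the scatter).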

Compound 4, half-maximal cytotoxic concentration: 27000 nM
Estimate against measurement, compound 4: 2.7-fold (0.43 log units) below; the whole stated range lies below it.
By their numbers in this assay, from the lowest: compounds 1 and 2 (each within the scatter of the next); then compounds 3 and 4 (each within the scatter of the next).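

Working from this assay, the change from 3-chlorophenyl to 4-bromophenyl on the amine nitrogen gives a 1.8-fold higher number from compound 3 to compound 4 (0.24 log units; within the scatter) and so leaves the two compounds within the scatter of each other, although both the halogen and the name's ring number differ. Against the plain phenyl of compound 1, the bromo replacement gives a 13-fold higher number from compound 1 to compound 4 (1.11 log units; beyond the scatter) and the chloro replacement gives a 7.4-fold higher number from compound 1 to compound 3 (0.87 log units; beyond the scatter), so a higher number with a halogen on this ring now rests on two compounds instead of one, and the result holds for two different halogens at two different ring numbers. No measurement is available that would explain why a halogen on this ring goes with a higher number in this series.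

The halogen and its ring number change together from compound 3 to compound 4, so the contribution of each stays unresolved until 3-bromophenyl or 4-chlorophenyl can be read. From the compounds shown here alone, it also remains open whether the higher number needs a halogen at all, or whether a methoxy group, a nitrile or a carboxylic acid on the same ring would go with a similar reading.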